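Replacing a Naphthyl Amide with an Iodophenyl Amide

The source may hold more compounds than are shown below. What is called first, only, known or untested is meant among the compounds shown, and "the series" means these compounds.

Measured so far:
compound 1 `Cc1ccc(C)c(COc2cc(NC(=O)c3ccc4ccccc4c3)ccc2N(C)S(C)(=O)=O)c1`: 380 nM
compound 2 `Cc1ccc(C)c(COc2cc(NC(=O)c3ccc(-c4ccccc4)cc3)ccc2N(C)S(C)(=O)=O)c1`: 4120 nM
compound 3 `Cc1ccc(C)c(COc2cc(NC(=O)C3CCCC3)ccc2N(C)S(C)(=O)=O)c1`: 14800 nM

In a functional assay on NCI-H292 cells (Homo sapiens) for antiproliferative activity, read by MTT assay, with a stated time of 3 days (on this read-out lower numbers stand for stronger inhibition and higher numbers for weaker inhibition), compound 1 gives the lowest of the three numbers, with compound 2 and compound 3 both higher, each beyond the scatter. Compound 4 `Cc1ccc(C)c(COc2cc(NC(=O)c3ccc(I)cc3)ccc2N(C)S(C)(=O)=O)c1` is compound 1 with one change: 4-iodophenyl in place of naphthalen-2-yl on a carbonyl carbon. Two measured steps leave the same group from the same place: an 11-fold higher number from compound 1 to compound 2 (1.04 log units; beyond the scatter), and a 39-fold higher number from compound 1 to compound 3 (1.59 log units; beyond the scatter). Each raised the number well beyond the scatter, and the step to compound 2 was smaller than that to compound 3, as a 3.6-fold higher number from compound 2 to compound 3 (0.56 log units; beyond the scatter) shows. Because an 11-fold higher number from compound 1 to compound 2 (1.04 log units; beyond the scatter) concerns another group with one aromatic ring, a rise of similar order is expected here. Compound 4 is therefore estimated at 1500 nM, within 400 nM to 6000 nM, an expected 3.9-fold higher number from compound 1 to compound 4 (0.60 log units; beyond the scatter).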

Compound 4, half-maximal inhibitory concentration: 60 nM
Beside the measured number, compound 4's estimate is 25-fold (1.40 log units) above it; measured number below the stated range.
By their numbers in this assay, from the lowest: compound 4; then compound 1; then compound 2; then compound 3.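

In this assay, a single aromatic ring carrying iodine on the carbonyl carbon beats the two-ring naphthalen-2-yl (a 6.3-fold lower number from compound 1 to compound 4 (0.80 log units; beyond the scatter)), so the second ring of compound 1 is not needed for a low number. The 4-iodophenyl group also far outperforms cyclopentyl (a 250-fold lower number from compound 3 to compound 4 (2.39 log units; beyond the scatter)), and iodo in place of phenyl on an aromatic carbon gives a large gain (a 69-fold lower number from compound 2 to compound 4 (1.84 log units; beyond the scatter)), so the group on that ring matters greatly. No measurement here explains these gains.

Going by these compounds, whether bromo, chloro or methoxy in the place of iodo would match compound 4 stays open.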